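A few compounds are considered here, and "the series" means these few. Any claim that something is new, unique, unknown or untested is made for them only; others in the source may bear on it.

Compounds measured in a physicochemical assay for permeability, using PAMPA; on this read-out lower numbers stand for lower permeability and higher numbers for higher permeability:
- compound 1, `CC[C@@H]1C[C@H](CC)CN(CCCNC(=O)C2CCN(Cc3nc(-c4ccccc4C)oc3C)CC2)C1`; in this assay compound 1 gives 1270 10^-6 cm/s.
- compound 2, `Cc1ccccc1-c1nc(CN2CCC(C(=O)NCCCN3CC(C)(C)CC(C)(C)C3)CC2)c(C)o1`; in this assay compound 2 gives only a limit, > 1390 10^-6 cm/s.
- compound 3, `Cc1oc(-c2ccccc2Cl)nc1CN1CCC(C(=O)NCCCN2C[C@H](C)C[C@H](C)C2)CC1`; in this assay compound 3 gives 352 10^-6 cm/s.

Compound 3 stands lowest of the two numbers given; the nearest number is that of compound 1, and the gap between them lies beyond the scatter. Compound 2 contributes a limit rather than a number.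

The next compound in the series is compound 4, `Cc1cccc(-c2nc(CN3CCC(C(=O)NCCCN4C[C@H](C)C[C@H](C)C4)CC3)c(C)o2)c1`. It differs from compound 3 in one place:
3-methylphenyl in place of 2-chlorophenyl on an aromatic carbon

For the measured compounds named here, only one measured step exists, an at least 1.0-fold higher number from compound 1 to compound 2 (0.03 log units; that floor lies within the scatter), and it alters the saturated ring on the chain, not the aryl group on the five-membered aromatic ring; its upper end is a limit, (the limit of > 1390 10^-6 cm/s in this assay, at which 1 of the 3 values shown sits). Going by the values given here, no measured step changes the aryl group, and compound 1 and compound 3 differ in two places, so their two values can only be read side by side. There is therefore nothing in hand that points to a step beyond the scatter for this change, and compound 4 is expected to sit close to compound 3, with a 1.2-fold higher number from compound 3 to compound 4 (0.08 log units; within the scatter) as the estimated step.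

Compound 4 is estimated at 420 10^-6 cm/s in this assay, expected between 200 10^-6 cm/s and 900 10^-6 cm/s.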

Compound 4, apparent permeability: 279 10^-6 cm/s
For compound 4 the middle estimate is 1.5-fold (0.18 log units) above the measured one; low and high end bracket the measured number.
By their numbers in this assay, from the lowest: compounds 4 and 3 (each within the scatter of the next); then compound 1. At a limit, above all of these: compound 2.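

The aryl group on the five-membered aromatic ring now has a measured step of its own in this assay: 3-methylphenyl in place of 2-chlorophenyl, with the rest of the structure unchanged, gives a 1.3-fold lower number from compound 3 to compound 4 (0.10 log units; within the scatter). For the compounds shown here, the earlier compounds offered no such reading, since the one step among them concerned the saturated ring on the chain, so this is the first evidence that this aryl position can take this exchange of groups, equal in heavy-atom count and both without net charge, with no step beyond the scatter. Nothing measured in the series gives a cause for this step, or for its small size.

As far as these compounds go, with only these two aryl groups compared in one place, it remains open whether a more different group at this position, such as a pyridine ring or a phenyl carrying a carboxylic acid or an amine, would give a step beyond the scatter. Going by these compounds alone, also open is whether the step seen here would hold with another saturated ring on the chain, as the aryl exchange has been read against only one such ring.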